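A few compounds are considered here, and "the series" means these few. Any claim that something is new, unique, unknown or untested is made for them only; others in the source may bear on it.

In a functional assay on SGC-7901 cells (Homo sapiens) for antiproliferative activity, read by MTT assay, with a stated time of 24 h (on this read-out lower numbers stand for stronger inhibition and higher numbers for weaker inhibition), compound 1 `O=C(NNc1ccccc1Cl)c1ccccc1NS(=O)(=O)c1cnc(O)nc1O` gives > 20000 nM, which is a limit and not a number. Compound 2 `O=C(NNc1ccc(F)cc1)c1ccccc1NS(=O)(=O)c1cnc(O)nc1O` gives > 20000 nM, also a limit, so its true value is not known. Both compounds share one mark, (the limit of > 20000 nM in this assay, at which 2 of the 2 values shown sit). Among the compounds with values here, the only measured step, a step that the two limits leave unreadable from compound 1 to compound 2, therefore offers no size to carry forward. Compound 3 `Cc1ccccc1C(=O)NNC(=O)c1ccccc1NS(=O)(=O)c1cnc(O)nc1O` carries (2-methylphenyl)carbonyl in place of 4-fluorophenyl on an amine nitrogen, ((2-methylphenyl)carbonyl in place of 4-fluorophenyl on an amine nitrogen). No clear gain or loss is expected in this assay, so the estimated change is only a step that the limit leaves unreadable from compound 2 to compound 3. For compound 3 the expected value is 25000 nM, within an estimated range of 12000 nM to 50000 nM.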

Compound 3, half-maximal inhibitory concentration: 13000 nM
Compound 3: the middle estimate sits 1.9-fold (0.28 log units) above what was measured; low and high end bracket the measured number.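

Compound 3 is the only compound shown with a measured number rather than a limit in this assay, so (2-methylphenyl)carbonyl on this amine nitrogen is the first change here to give a readable value: the limit of > 20000 nM in this assay, at which 2 of the 3 values shown sit.

Against the 4-fluorophenyl group the change gives an at least 1.5-fold lower number from compound 2 to compound 3 (0.18 log units; that floor lies within the scatter), and against the 2-chlorophenyl group it gives an at least 1.5-fold lower number from compound 1 to compound 3 (0.18 log units; that floor lies within the scatter). On these data alone, both are only floors, so the true sizes remain unknown.

As far as these compounds go, it remains open whether the carbonyl or the methyl matters, and how an acetyl group or an unsubstituted phenylcarbonyl would compare.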